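Swapping an Isopropylamino for an Open Diamine Chain

The compounds below may be only part of what the source reports. "The series", "measured", "known", "first", "only" and "open" are said of these compounds alone.

Of the compounds shown here, two built on a shared core have been tested in a functional assay on SK-MEL-2 cells (Homo sapiens) for cytotoxicity, read by sulforhodamine B assay; a lower number here means a stronger inhibitor, a higher number a weaker inhibitor. Compound 1 `CN1CCCN(c2nc(-c3ccccc3)nc3ccccc23)CC1` gives 36.6 ug/mL. Going by the values given here, compound 2 `CC(C)Nc1nc(-c2ccccc2)nc2ccccc12` gives 16.5 ug/mL, the lowest of the two numbers, and the step of a 2.2-fold lower number from compound 1 to compound 2 (0.35 log units; beyond the scatter) is the only measured change at this position. Compound 3 `CN(C)CCN(C)c1nc(-c2ccccc2)nc2ccccc12` differs from compound 2 by (2-(dimethylamino)ethyl)(methyl)amino in place of isopropylamino on an aromatic carbon. The entering group brings back a basic-looking chain nitrogen of the kind found in the ring of compound 1, though here in an open chain, and it removes the hydrogen-bond donor of compound 2. Among the compounds with values here, the one step that bears on this, a 2.2-fold lower number from compound 1 to compound 2 (0.35 log units; beyond the scatter), was modest, so a comparable move back toward compound 1 seems the likeliest outcome. Compound 3 is thus expected to show a 1.7-fold higher number from compound 2 to compound 3 (0.23 log units; within the scatter). Compound 3 is estimated at 28 ug/mL, within 12 ug/mL to 60 ug/mL.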

Compound 3, half-maximal inhibitory concentration: 28.9 ug/mL
Beside the measured number, compound 3's estimate is 1.0-fold (0.01 log units) below it; measured number inside the range.
By their numbers in this assay, from the lowest: compounds 2, 3 and 1 (each within the scatter of the next, the first and the last beyond it).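

In this assay the open chain (2-(dimethylamino)ethyl)(methyl)amino cannot be told apart from either of the other two groups at this position: the result is a 1.8-fold higher number from compound 2 to compound 3 (0.24 log units; within the scatter) on one side and a 1.3-fold lower number from compound 1 to compound 3 (0.10 log units; within the scatter) on the other. Only compound 1 and compound 2 stand apart beyond the scatter, so the three groups cover a narrow span, and replacing the 4-methyl-1,4-diazepan-1-yl ring with an open chain leaves no readable change. Nothing measured here explains these numbers.

From the compounds shown here alone, a 2-(dimethylamino)ethylamino group would keep the chain while restoring the hydrogen on the attached nitrogen, and how it would compare remains open. So does whether a plain amino group or a longer chain would move the number beyond the scatter.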